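The source may report more compounds than this note shows. Statements on the series, on what has been measured and on what is new or still open speak of the compounds shown alone.

Measured compounds in an assay for binding affinity to melatonin receptor (Gallus gallus); on this read-out higher numbers stand for weaker inhibition and lower numbers for stronger inhibition: compound 1 `COc1cccc(CCCNC(C)=O)c1` with 63 nM; compound 2 `CC(=O)NCCCc1cccc(F)c1` with 1920 nM.

Compound 2 gives the highest number of the two, the nearest being compound 1, and the step of a 30-fold higher number from compound 1 to compound 2 (1.48 log units; beyond the scatter) lies beyond the scatter. Compound 3 `CCC(=O)NCCCc1cccc(F)c1` is not yet measured in this assay. Against compound 2 it differs by methyl in place of hydrogen on a saturated chain carbon bound to a carbonyl carbon. Within the data shown here, no measured step concerns the amide side: the only step on record, a 30-fold higher number from compound 1 to compound 2 (1.48 log units; beyond the scatter), changes the substituent on the aromatic carbon and says nothing about methyl in place of hydrogen on a saturated chain carbon bound to a carbonyl carbon. Among the measured compounds shown here, with no step bearing on this change, the expectation for compound 3 is a step of a 1.6-fold lower number from compound 2 to compound 3 (0.20 log units; within the scatter) that stays within or close to the scatter, in either direction. Compound 3 is estimated at 1200 nM in this assay, with a range from 300 nM to 4000 nM.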

Compound 3, inhibition constant: 740 nM
Compound 3: middle estimate off by 1.6-fold (0.21 log units), on the high side; the measured number falls inside the stated range.
By their numbers in this assay, from the lowest: compound 1; then compound 3; then compound 2.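

In this assay, the amide side of the series now has its first reading: methyl in place of hydrogen on a saturated chain carbon bound to a carbonyl carbon, read also as acetyl to propanoyl, gives a modest step (a 2.6-fold lower number from compound 2 to compound 3 (0.41 log units; beyond the scatter)). Among these compounds, the earlier step concerned only the substituent on the aromatic carbon, so this is the first sign that the number responds to a change on the acyl side, here toward stronger inhibition with fluoro held constant. Nothing on hand accounts for this shift.

On these data alone, whether the same change carries over to the methoxy compound remains open, since this step has been read only with fluoro on the aromatic carbon. Also open, as far as these compounds go, is how far the trend runs along the acyl chain, for example with a longer chain such as butanoyl or with a cyclopropyl group at this place.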